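Notes: 3-methylphenyl to 4-methylphenyl, compound 3 to compound 4

The compounds below may be only part of what the source reports. "The series", "measured", "known", "first", "only" and "open" are said of these compounds alone.

Measured in a functional assay on M21 cells (Homo sapiens) for antiproliferative activity, read by sulforhodamine B assay, with a stated time of 48 h; a lower number here means a stronger inhibitor, a higher number a weaker inhibitor:
- compound 1 `CCCN1CCN(c2ccc(S(=O)(=O)Oc3ccccc3OC)cc2)C1=O`: > 100000 nM (a limit of the assay, not a number)
- compound 2 `CCCN1CCN(c2ccc(S(=O)(=O)Oc3ccc(C)cc3C)cc2)C1=O`: 9700 nM
- compound 3 `CCCN1CCN(c2ccc(S(=O)(=O)Oc3cccc(C)c3)cc2)C1=O`: 28000 nM

Compound 3 holds the higher of the two exact numbers. Its nearest neighbour is compound 2, with a 2.9-fold higher number from compound 2 to compound 3 (0.46 log units; beyond the scatter).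

Compound 4 `CCCN1CCN(c2ccc(S(=O)(=O)Oc3ccc(C)cc3)cc2)C1=O` is still unmeasured. The change is 4-methylphenyl in place of 3-methylphenyl on an oxygen.

The closest guide is that modest step, since compound 2 carries 2,4-dimethylphenyl and gives 9700 nM. The steps of an at least 10-fold lower number from compound 1 to compound 2 (1.01 log units; beyond the scatter) and an at least 3.5-fold lower number from compound 1 to compound 3 (0.55 log units; beyond the scatter) both start from a limit and bear only weakly here.

No step beyond the scatter is expected in this assay, with a slight lean towards a lower number. The expected step is a 1.6-fold lower number from compound 3 to compound 4 (0.19 log units; within the scatter).

For compound 4 the estimated value is 18000 nM, with an expected range of 7000 nM to 50000 nM.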

Compound 4, half-maximal inhibitory concentration: 28000 nM
Compound 4: the middle estimate sits 1.6-fold (0.19 log units) below what was measured, within the range that was stated.
By their numbers in this assay, from the lowest: compound 2; then compounds 3 and 4 (each within the scatter of the next). At a limit, above all of these: compound 1.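

In this assay, 4-methylphenyl in place of 3-methylphenyl on the oxygen bound to the sulfonyl sulfur gives no change at the digits printed from compound 3 to compound 4 (within the scatter), so these two placements of a single methyl are not told apart. Hydrogen in place of methyl on an aromatic carbon gives a 2.9-fold higher number from compound 2 to compound 4 (0.46 log units; beyond the scatter), so in this pair the extra methyl of 2,4-dimethylphenyl counts. The remaining step, an at least 3.5-fold lower number from compound 1 to compound 4 (0.55 log units; beyond the scatter), starts from a limit and gives only a bound: the limit of > 100000 nM in this assay, at which 1 of the 4 values shown sits.

Open, as far as these compounds go, is whether 2-methylphenyl alone would match 2,4-dimethylphenyl. Also open, from the compounds shown here alone, is how an amine or a carboxylic acid on this ring would read.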